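This account rests on a few compounds, and the source may have more. Where it says the series, first, only, none or still open, it means among the compounds named here.

Compound 1 `Cc1nnc(SCC(=O)N/N=c2/scc(-c3ccccc3)n2-c2ccccc2)s1`: > 200 ug/mL
Compound 2 `O=C(CSc1ncccn1)N/N=c1/scc(-c2ccccc2)n1-c1ccccc1`: "not determined" (no result reported)

In a functional assay on C6 cells (Rattus norvegicus) for cytotoxicity, read by MTT assay, with a stated time of 24 h (a higher number here means a weaker inhibitor, a lower number a stronger inhibitor), compound 1 gives > 200 ug/mL, which is a limit of the assay and not a number. For compound 2 this assay reports no result, so compound 1 has no measured neighbour to compare against and no step between measured compounds can be shown.

Compound 3 `COc1ccc(-c2cs/c(=N/NC(=O)CSc3nnc(C)s3)n2-c2ccccc2)cc1` differs from compound 1 in one place: methoxy in place of hydrogen on an aromatic carbon. No measured step tells how such a change moves this assay, so the step is estimated as none beyond the scatter, because compound 1 sits at the limit of > 200 ug/mL in this assay, at which 1 of the 2 values shown sits, and the data give no reason to expect a move in either direction.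

The expected step from compound 1 to compound 3 is a step that the limit leaves unreadable from compound 1 to compound 3. Compound 3 is thus estimated at 250 ug/mL in this assay, with a range from 100 ug/mL to 600 ug/mL.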

Compound 3, half-maximal inhibitory concentration: 18.7 ug/mL
Compound 3: the middle estimate sits 13-fold (1.13 log units) above what was measured; measured number below the stated range.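

In this assay, the change from phenyl to 4-methoxyphenyl, on a six-membered aromatic ring of carbon only and para to a large group, gives an at least 10-fold lower number from compound 1 to compound 3 (1.02 log units; beyond the scatter), the first sign that this position can move the read-out. Compound 1 gives > 200 ug/mL, which is a limit of the assay and not a number. The step therefore gives only a minimum size and not an exact one, because one of its two ends is such a limit: the limit of > 200 ug/mL in this assay, at which 1 of the 3 values shown sits.

Methoxy is the only replacement for hydrogen at this position among the compounds shown, so it stays open whether a hydroxyl group, a chlorine atom or a longer ether such as ethoxy would act in the same way. On these data alone, it also stays open whether this change would carry over to a compound that differs at the other end of the molecule, such as compound 2.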